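Aryl sulfonyl swap on a shared core: maximal response

The compounds below may be only part of what the source reports. "The series", "measured", "known", "first", "only" and "open" are said of these compounds alone.

Compound 1 `CC(C)Cn1nc(S(=O)(=O)c2cccc3ccccc23)c2cc(N3CCN(C)CC3)ccc21` and compound 2 `COc1cccc(S(=O)(=O)c2n[nH]c3ccc(N4CCN(C)CC4)cc23)c1` share the same core and differ in the group on the sulfonyl sulfur. In a functional assay on HeLa cells for antagonist activity at 5-hydroxytryptamine receptor 6 (Homo sapiens) (on this read-out lower numbers stand for smaller maximal responses and higher numbers for larger maximal responses), compound 1 gives 100%. In this assay compound 2 gives 100%, level with compound 1 at the digits shown, so the two stand within the usual scatter of each other; no change between them is claimed.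

Compound 3 `CN1CCN(c2ccc3[nH]nc(S(=O)(=O)c4ccc(Cl)cc4)c3c2)CC1` follows from compound 2 by a single change, (4-chlorophenyl in place of 3-methoxyphenyl on a sulfonyl sulfur), a 4-chlorophenyl in place of a 3-methoxyphenyl on the sulfonyl sulfur. The two measured compounds both reach the full maximal response, so the expected step from compound 2 to compound 3 in this assay is none beyond the scatter, no change at the digits printed from compound 2 to compound 3 (within the scatter). Compound 3 is therefore estimated to give 100% in this assay, with an expected range from 85% to 105%.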

Compound 3, largest response reached (reported as Imax), in percent of the reference or control that the assay uses: 100%
Estimate against measurement, compound 3: no gap at the digits printed; low and high end bracket the measured number.
By their numbers in this assay, from the lowest: compounds 1, 2 and 3 (each within the scatter of the next).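

In this assay, within the data shown here, the swap of 3-methoxyphenyl for 4-chlorophenyl on the sulfonyl sulfur gives no change at the digits printed from compound 2 to compound 3 (within the scatter) and this is the first comparison here in which only one group changes. On this read-out, then, a phenyl ring carrying chlorine serves at this position as well as one carrying a methoxy group, even though the group on the ring and its place both differ. Nothing at hand explains why the maximal response stays level.

As far as these compounds go, whether the sulfonyl sulfur keeps this response with something other than a substituted phenyl ring, such as a saturated cyclohexyl ring, or with a carboxylic acid on the phenyl ring, remains open. A maximal response also does not tell how much of each compound is needed to reach it.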